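The compounds below may be only part of what the source reports. "The series", "measured", "known", "first", "only" and "open" are said of these compounds alone.

Series notes, cytotoxicity on prostate carcinoma cells.

Of the compounds shown here, three have numbers so far in a functional assay on PC-3 cells (Homo sapiens) for cytotoxicity, read by MTT assay, with a stated time of 72 h; on this read-out higher numbers stand for weaker inhibition of growth and lower numbers for stronger inhibition of growth. Compound 1 `CS/C(=N\C(=O)c1cc(-c2ccccc2)nc2ccccc12)NC(=O)c1cc(-c2ccccc2)nc2ccccc12` gives 7480 nM in this assay. Compound 2 `O=C(/N=C(/NC(=O)c1csc([N+](=O)[O-])c1)[Se]Cc1ccccc1)c1csc([N+](=O)[O-])c1` gives 35900 nM, and compound 3 `CS/C(=N\C(=O)c1cnc2ccccc2c1)NC(=O)c1cnc2ccccc2c1` gives 76300 nM. Compound 1 stands at the lowest number of the three; compound 2 is the nearest to it and compound 3 the furthest, and both of those gaps lie beyond the usual scatter of this assay. For the measured compounds named here, no pair among the measured compounds differs in one place only, so no single structural step has yet been measured, and the relation between the two pairs of core types and their linkers remains unresolved.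

The next compound, compound 4 `C[Se]/C(=N\C(=O)c1cc(-c2ccccc2)nc2ccccc12)NC(=O)c1cc(-c2ccccc2)nc2ccccc12`, keeps the whole of compound 1 apart from one exchange: a group of 2 heavy atoms (1 carbon, 1 selenium; no ring) in place of a group of 2 heavy atoms (1 carbon, 1 sulfur; no ring), on a carbon with a double bond to nitrogen

Going by the values given here, nothing among the measured compounds speaks to this exchange. Among the compounds with values here, with no measured step of this kind to rest on, the working expectation is a step from compound 1 to compound 4 that stays within the scatter, or at most a mild lowering of the number, since the core and both amide-type arms are unchanged. The estimated step of a 1.5-fold lower number from compound 1 to compound 4 (0.17 log units; within the scatter) reflects that view. Compound 4 is thus expected to give about 5000 nM in this assay, within a range from 1500 nM to 16000 nM.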

Compound 4, concentration for 50% growth inhibition: 3970 nM
Compound 4: middle estimate off by 1.3-fold (0.10 log units), on the high side, and the stated range covers the measured number.
By their numbers in this assay, from the lowest: compounds 4 and 1 (each within the scatter of the next); then compound 2; then compound 3.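

In this assay, the step at this position, a 1.9-fold lower number from compound 1 to compound 4 (0.28 log units; within the scatter), lies within the scatter, so the measured pair gives no separation between methylsulfanyl and the group of 1 carbon and 1 selenium. For the compounds shown here, this is the first single-place step, and it shows that on the core of compound 1, with both amide-type arms kept, the exchange on a carbon with a double bond to nitrogen leaves growth inhibition at a level that repeated measurement could not tell apart. No measurement at hand bears on this step, and the pair can be read only as a comparison of the two numbers.

On these data alone, whether an amine, a hydroxyl group or a longer alkyl chain on the sulfur or selenium in this place would move the number beyond the scatter remains open. Also open, as far as these compounds go, is whether the same exchange of sulfur for selenium would give a step of similar size on the core of compound 3, since this single pair speaks only for the core of compound 1.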